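This account rests on a few compounds, and the source may have more. Where it says the series, first, only, none or still open, it means among the compounds named here.

Working notes on the series sharing the core of compound 1 `CCc1ccccc1N(CC(=O)NCc1ccc(Cl)cc1)S(=O)(=O)c1ccc(C)cc1`, compound 2 `CCc1ccccc1N(CC(=O)NCc1ccc(Br)cc1)S(=O)(=O)c1ccc(C)cc1` and compound 3 `CCc1ccccc1N(CC(=O)NCc1ccc(C(F)(F)F)cc1)S(=O)(=O)c1ccc(C)cc1`. In a functional assay on CHO-K1 cells for antagonist activity at prostaglandin E2 receptor EP1 subtype (Homo sapiens), read by FLIPR and calcium flux (a higher number here means a weaker inhibitor, a lower number a stronger inhibitor), compound 1 gives 11.5 nM, compound 2 gives 22.9 nM and compound 3 gives 209 nM. Compound 3 thus carries the highest number of the three: an 18-fold higher number from compound 1 to compound 3 (1.26 log units; beyond the scatter) and a 9.1-fold higher number from compound 2 to compound 3 (0.96 log units; beyond the scatter), whereas a 2.0-fold higher number from compound 1 to compound 2 (0.30 log units; within the scatter). Compound 4 `CCc1ccccc1N(CC(=O)NCc1ccccc1F)S(=O)(=O)c1ccc(C)cc1` differs from compound 3 by 2-fluorophenyl in place of 4-(trifluoromethyl)phenyl on a saturated chain carbon bound to an amide-type nitrogen. For the measured compounds named here, no measured step covers this exact change, but the two steps that bear on it show a single halogen in place of trifluoromethyl running to markedly lower numbers, so a lower number in this assay is expected, roughly a 6.0-fold lower number from compound 3 to compound 4 (0.78 log units; beyond the scatter), with the uncertainty widened since the fluorine site has no precedent here. Compound 4 is accordingly estimated at 35 nM, within 8 nM to 150 nM.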

Compound 4, inhibition constant: 135 nM
Beside the measured number, compound 4's estimate is 3.9-fold (0.59 log units) below it; the measured number falls inside the stated range.
By their numbers in this assay, from the lowest: compounds 1 and 2 (each within the scatter of the next); then compounds 4 and 3 (each within the scatter of the next).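

In this assay, 2-fluorophenyl in place of 4-(trifluoromethyl)phenyl gives a 1.5-fold lower number from compound 3 to compound 4 (0.19 log units; within the scatter), so a single halogen at this position does not by itself bring the number down to those of the chloro and bromo compounds: a 5.9-fold higher number from compound 2 to compound 4 (0.77 log units; beyond the scatter) and a 12-fold higher number from compound 1 to compound 4 (1.07 log units; beyond the scatter). These steps change the halogen and its site together, and the two cannot be separated here. Nothing available explains the gap to compounds 1 and 2.

Still open, going by these compounds, is how 4-fluorophenyl or 2-chlorophenyl would read here, which would separate halogen from site. Also open, on these data alone, is whether an amine or a carboxylic acid in place of the halogen would keep any of this activity.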